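The source may report more compounds than this note shows. Statements on the series, on what has been measured and on what is new or still open speak of the compounds shown alone.

Two compounds of the series have results in an ADME assay on HCT-116 cells (Homo sapiens) for antiproliferative activity; a lower number here means a stronger inhibitor, a higher number a weaker inhibitor. Compound 1 `COc1ccc(C(=O)O)cc1COc1ccc(Cl)c(C)c1` sits at the limit of > 50000 nM there, a limit of the assay and not a number. That limit is the one at which one of the two values sits (the limit of > 50000 nM in this assay, at which 1 of the 2 values shown sits). Compound 2 `COc1ccc(C(N)=O)cc1/C=C/c1ccc(Cl)cc1` gives 7100 nM in this assay, the only number shown, so it stands alone without a measured step. Compound 3 `COc1ccc(/C=C/c2cc(C(N)=O)ccc2OC)cc1` differs from compound 2 by methoxy in place of chloro on an aromatic carbon. Among the compounds with values here, with no measured step to lean on, only a small shift is expected, a 1.3-fold higher number from compound 2 to compound 3 (0.10 log units; within the scatter), in no clear direction beyond the scatter. Compound 3 is estimated at 9000 nM in this assay, within 3000 nM to 30000 nM.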

Compound 3, half-maximal inhibitory concentration: 19000 nM
Estimate against measurement, compound 3: 2.1-fold (0.32 log units) below, within the range that was stated.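

Methoxy in place of chloro on an aromatic carbon, para to a large group, gives a 2.7-fold higher number from compound 2 to compound 3 (0.43 log units; beyond the scatter) in this assay, the first measured step in the series. This position is therefore not indifferent to its substituent, and compound 2 with chloro is the stronger inhibitor of this pair. Nothing given here bears on the reason for this step.

Only chloro and methoxy can be compared at this position. As far as these compounds go, whether a methyl, a fluoro or an amine would stand closer to chloro or to methoxy remains open.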